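The source may report more compounds than this note shows. Statements on the series, on what has been measured and on what is new or still open speak of the compounds shown alone.

Among the compounds with values here, compound 1 `COc1cc(C(=O)N2C[C@@H](n3cc(C4CC4)nn3)C[C@H]2C(=O)N[C@H]2C[C@@H]2c2ccccc2)ccc1CN` gives 960 nM in an assay on isolated protein for inhibition of serine protease 1 (Homo sapiens), read by fluorescence (on this read-out higher numbers stand for weaker inhibition and lower numbers for stronger inhibition), the higher of the two numbers measured so far. Its neighbour compound 2 `COc1cc(C(=O)N2C[C@@H](n3cc(C4CC4)nn3)C[C@H]2C(=O)N[C@H]2CCCC[C@@H]2c2ccccc2)ccc1CN` gives 19 nM, and the move a 51-fold lower number from compound 1 to compound 2 (1.70 log units; beyond the scatter) shows how much a larger saturated ring at that amide can change the read-out. Compound 3 `COc1cc(C(=O)N2C[C@@H](n3cc(C4CC4)nn3)C[C@H]2C(=O)N2CC[C@@H](c3ccccc3)C2)ccc1CN` carries a different change at the same carbonyl: 3-phenylpyrrolidin-1-yl in place of (2-phenylcyclopropyl)amino on a carbonyl carbon. Within the data shown here, only that single measured step bears on it, and it points toward a lower number, though the loss of the amide hydrogen is untested, so a moderate fall is expected, a 3.2-fold lower number from compound 1 to compound 3 (0.51 log units; beyond the scatter). Compound 3 is therefore estimated at 300 nM, between 60 nM and 1500 nM.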

Compound 3, half-maximal inhibitory concentration: 330 nM
Beside the measured number, compound 3's estimate is 1.1-fold (0.04 log units) below it, within the range that was stated.
By their numbers in this assay, from the lowest: compound 2; then compound 3; then compound 1.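

The change at this carbonyl carbon does not need the amide hydrogen to keep the number from rising: 3-phenylpyrrolidin-1-yl lacks that hydrogen, and in this assay the swap still gives a 2.9-fold lower number from compound 1 to compound 3 (0.46 log units; beyond the scatter) on this read-out. The ring and the amide hydrogen change together here, so this step cannot separate their contributions. Nothing measured beyond these numbers explains the step.

An N-methyl amide of compound 1 would test the loss of that hydrogen with the three-membered ring kept. As far as these compounds go, whether a 3-phenylpiperidin-1-yl group at this carbonyl carbon lowers the number further remains open.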